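Chloro for butyl on the benzamide of compound 1

The source may hold more compounds than are shown below. What is called first, only, known or untested is meant among the compounds shown, and "the series" means these compounds.

Working notes on a small benzamide series. The read-out throughout is a functional assay on the whole organism (stomach) with Rattus norvegicus as the target; a higher number here means that more compound is needed for the effect, a lower number that less compound is needed. Among the measured compounds shown here, compound 1, `CCCCc1ccc(C(=O)Nc2cc(C(=O)O)cc(C(=O)O)c2)cc1`, gives 91.9 mg/kg, the highest of the three numbers so far. Compound 3, `N#Cc1ccc(C(=O)Nc2cc(C(N)=O)cc(C(=O)O)c2)cc1`, gives 87.2 mg/kg, which lies within the scatter of compound 1, so no order between these two is claimed. Compound 2, `N#Cc1ccc(C(=O)Nc2cccc(-c3nn[nH]n3)c2)cc1`, gives 21.4 mg/kg, a number beyond the scatter below compound 1; of the measured set, compound 2 is the one that needs the least compound.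

Compound 4, `O=C(O)c1cc(NC(=O)c2ccc(Cl)cc2)cc(C(=O)O)c1`, is not yet measured. It differs from compound 1 in one place: chloro in place of butyl on an aromatic carbon. The change sits on the benzamide ring, para to a large group, and touches nothing on the diacid side.

For the measured compounds named here, no measured pair here shows the effect of exchanging this group, and compounds 2 and 3 differ from compound 1 in more than this one place, so they give no clean guide. The expectation is therefore a step of little size, at most a modest move toward a lower number, and quite possibly none beyond the scatter: the estimated step is a 1.3-fold lower number from compound 1 to compound 4 (0.12 log units; within the scatter). For compound 4 the estimate in this assay is 70 mg/kg, with a range from 25 mg/kg to 200 mg/kg.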

Compound 4, dose for 50% inhibition: 97.3 mg/kg
Compound 4: middle estimate off by 1.4-fold (0.14 log units), on the low side; the range from low to high includes it.
By their numbers in this assay, from the lowest: compound 2; then compounds 3, 1 and 4 (each within the scatter of the next).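

Chloro in place of butyl on an aromatic carbon, para to a large group, gives in this assay the series' first step that can be read for a single change: a 1.1-fold higher number from compound 1 to compound 4 (0.02 log units; within the scatter). The exchange takes this place from 4 heavy atoms of carbon to 1 chlorine atom with the rest of the core of compound 1 held fixed, yet the two numbers cannot be told apart. For these two groups at this place, the number therefore stays within the scatter, and nothing at hand accounts for this result.

From the compounds shown here alone, it remains open whether a different kind of group at this place, such as an amine or a longer chain than butyl, would move the number beyond the scatter, since butyl and chloro are only two points at one position. Compound 2 and compound 3 differ from compound 1 in more than one place, so the part of the core that goes with the lower number of compound 2 cannot be assigned from the compounds shown.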